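Nitro-to-nitrile swap on the bis-benzylidene piperidinone series

This account rests on a few compounds, and the source may have more. Where it says the series, first, only, none or still open, it means among the compounds named here.

The series is built on a bis-benzylidene piperidinone core carrying an aryl sulfonyl group on the ring nitrogen. Compound 1 `COc1cc(/C=C2\CN(S(=O)(=O)c3ccc(F)cc3)C/C(=C\c3cccc([N+](=O)[O-])c3)C2=O)cc(OC)c1OC` and compound 2 `COc1cc(/C=C2\CN(S(=O)(=O)c3ccc(F)cc3)C/C(=C\c3ccc(C#N)cc3)C2=O)cc(OC)c1OC` share one core; compound 3 `CC(=O)Nc1ccc(S(=O)(=O)N2C/C(=C\c3cccc([N+](=O)[O-])c3)C(=O)/C(=C/c3ccccc3F)C2)cc1` and the unmeasured compound 4 `CC(=O)Nc1ccc(S(=O)(=O)N2C/C(=C\c3ccc(C#N)cc3)C(=O)/C(=C/c3ccccc3F)C2)cc1` share another. The difference between the two cores is not broken down here.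

In a functional assay on QGY-7703 cells (Homo sapiens) for cytotoxicity, read by MTT assay, with a stated time of 24 h (a higher number here means a weaker inhibitor, a lower number a stronger inhibitor), compound 1 gives 3270 nM. Compound 2 gives 4980 nM in this assay, the step being a 1.5-fold higher number from compound 1 to compound 2 (0.18 log units; within the scatter) for the change (4-cyanophenyl in place of 3-nitrophenyl on a double-bonded chain carbon bound to a double-bonded ring carbon). Compound 3 gives 7850 nM in this assay; its number is higher than that of compound 1 by a step beyond the scatter, while against compound 2 the two values sit within the scatter of each other, so no order between them is claimed.

Compound 4 is related to compound 3 by the same change, (4-cyanophenyl in place of 3-nitrophenyl on a double-bonded chain carbon bound to a double-bonded ring carbon), on the same place. On the first core this change moved the number only within the scatter, and nothing here suggests the second core would answer differently, so the step from compound 3 to compound 4 is expected to be of similar size, about a 1.5-fold higher number from compound 3 to compound 4 (0.17 log units; within the scatter), because of a 1.5-fold higher number from compound 1 to compound 2 (0.18 log units; within the scatter). Compound 4 is therefore estimated at 11500 nM in this assay, with a likely range of 6000 nM to 22000 nM.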

Compound 4, half-maximal inhibitory concentration: 2050 nM
The estimate for compound 4 lay 5.6-fold (0.75 log units) above the measured number, and the stated range ends above it.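

In this assay, putting 4-cyanophenyl in place of 3-nitrophenyl does not carry over as a constant step from one core to the other: the same change on two cores in this assay, a 1.5-fold higher number (0.18 log units; within the scatter) from compound 1 to compound 2 and a 3.8-fold lower number (0.58 log units; beyond the scatter) from compound 3 to compound 4, 5.8-fold (0.77 log units) apart, beyond the scatter of two such steps

On the core of compound 3, the change gives a 3.8-fold lower number from compound 3 to compound 4 (0.58 log units; beyond the scatter), whereas on the core of compound 1 the same change stays within the scatter, so in this series the step read on one core cannot stand in for the step on the other. The cores differ in more than one place, and these two pairs show neither which difference goes with the gap nor why the step depends on the core.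

Still open, on these data alone, is how the number would move on either core if the 3-nitrophenyl gave way to a phenyl ring carrying a carboxylic acid or an amine. Also open, as far as these compounds go, is which part of the core matters, which the same pair of groups could show on a core differing from the core of compound 3 in one place only.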